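The source may hold more compounds than are shown below. What is called first, only, known or untested is meant among the compounds shown, and "the series" means these compounds.

Measured so far in a functional assay on Ehrlich cells (Mus musculus) for cytotoxicity, tested at 25 ug/mL; a lower number here means a weaker effect, a higher number a stronger effect of the compound at the concentration tested:
compound 1 `COc1cc(N2C(N)=C(C#N)C(c3ccc(OC)c4ccccc34)C3=C2CC(C)(C)CC3=O)cc(OC)c1OC`: 30%
compound 2 `COc1cc(N2C(N)=C(C#N)C(c3ccc(Cl)cc3Cl)C3=C2CC(C)(C)CC3=O)cc(OC)c1OC`: 55%
compound 3 `COc1cc(N2C(N)=C(C#N)C(c3ccccc3Cl)C3=C2CC(C)(C)CC3=O)cc(OC)c1OC`: 15%

Compound 2 stands highest of the three in this assay; its nearest neighbour is compound 1 and the furthest is compound 3, both gaps beyond the scatter. Compound 4 `COc1cc(N2C(N)=C(C#N)C(c3ccccc3)C3=C2CC(C)(C)CC3=O)cc(OC)c1OC` is not yet measured. The change from compound 2 to compound 4 is phenyl in place of 2,4-dichlorophenyl on a saturated ring carbon.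

The step that bears most directly is a number 40 percentage points lower from compound 2 to compound 3 (beyond the scatter), where one chloro was replaced by hydrogen and the read-out fell sharply. The steps of a number 25 percentage points higher from compound 1 to compound 2 (beyond the scatter) and a number 15 percentage points lower from compound 1 to compound 3 (beyond the scatter) show the same ordering of the dichloro and monochloro variants. Removing both chloro groups is therefore expected to give a large step downward, a number 40 percentage points lower from compound 2 to compound 4 (beyond the scatter), and compound 4 is expected to read about 15%, within 5% to 35%.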

Compound 4, a percentage reported as activity, at one concentration (the size of the read-out at that concentration, not a potency): 6%
The estimate for compound 4 lay 9 percentage points above the measured number; the range from low to high includes it.
By their numbers in this assay, from the lowest: compounds 4 and 3 (each within the scatter of the next); then compound 1; then compound 2.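

Phenyl on this saturated ring carbon gives the unsubstituted reference for the series (this assay), and losing both chloro groups is a large step (a number 49 percentage points lower from compound 2 to compound 4 (beyond the scatter)). Going by these compounds alone, the single chloro of compound 3 does not separate it from phenyl (a number 9 percentage points lower from compound 3 to compound 4 (within the scatter)), so among the chloro variants only 2,4-dichlorophenyl stands clear of it. The 4-methoxynaphthalen-1-yl group also stands clear of phenyl (a number 24 percentage points lower from compound 1 to compound 4 (beyond the scatter)). Open, on these data alone, is whether a 4-chlorophenyl group alone would restore the read-out, or what an amine or carboxylic acid on the phenyl would do. No measurement shown gives a reason for these steps.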